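The source may hold more compounds than are shown below. What is called first, only, known or untested is meant among the compounds shown, and "the series" means these compounds.

Of the compounds shown here, two that share a core have been tested in a functional assay on the whole organism for inhibition, with Rattus norvegicus as the target, at a dose of 25 mg/kg by the intraperitoneal route; a lower number here means less inhibition, a higher number more inhibition at the dose given (going by the name of the read-out). Compound 1 `CC(C)N(C)c1ncnc2c1ncn2CC1CC1` gives 32%. Compound 2 `c1ccc(Nc2ncnc3c2ncn3CC2CC2)cc1` gives 0%, the lowest of the two numbers, and its gap to compound 1 lies beyond the usual scatter. Compound 3 `c1nc(NC2CCC2)c2ncn(CC3CC3)c2n1` has not yet been measured. It differs from compound 2 in one place: cyclobutyl in place of phenyl on a nitrogen on an aromatic ring. Within the data shown here, no step between two measured compounds covers this change, so the expectation rests only on what the two measured compounds show. Compound 1, which carries no phenyl, gives 32%, while compound 2, which does carry the phenyl, gives 0%. On that basis compound 3 is expected to rise in this assay by a step of a number 25 percentage points higher from compound 2 to compound 3 (beyond the scatter), beyond the scatter. The estimate for compound 3 is 25%, with a range from 5% to 50%.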

Compound 3, a percentage reported as inhibition, in the whole organism at one dose (the size of the read-out at that dose, not a potency): 0%
Compound 3: middle estimate off by 25 percentage points, on the high side, outside the stated range (below it).
By their numbers in this assay, from the lowest: compounds 2 and 3 (each within the scatter of the next); then compound 1.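

Exchanging phenyl for cyclobutyl on a nitrogen on an aromatic ring gives no change at the digits printed from compound 2 to compound 3 (within the scatter) in this assay, so at this position the aromatic ring of compound 2 is not what separates it from compound 1. Cyclobutylamino in place of isopropyl(methyl)amino on an aromatic carbon gives a number 32 percentage points lower from compound 1 to compound 3 (beyond the scatter), which ties the difference to the make-up of the amino group rather than to phenyl alone. No measured evidence explains this difference.

The compounds shown leave open whether a methyl group added to the nitrogen of compound 3 would restore the read-out, or whether it depends on the isopropyl group. They also leave open how a smaller dimethylamino group or an open-chain isopropylamino group would read at this position.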